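Methoxybenzyl to hydroxybenzyl on a triazole amide series

The source may report more compounds than this note shows. Statements on the series, on what has been measured and on what is new or still open speak of the compounds shown alone.

The measured compounds:
compound 1, `COc1cc2c(cc1OC)CN(CCCCNC(=O)c1c[nH]nn1)CC2`, 11000 nM in an assay on membranes from brain for displacement of a labelled ligand from Sigma non-opioid intracellular receptor 1 (Cavia porcellus), read by scintillation counting, with a stated time of 90 min; on this read-out lower numbers stand for stronger inhibition and higher numbers for weaker inhibition
compound 2, `COc1ccccc1Cn1cc(C(=O)NCCCCN2CCc3cc(OC)c(OC)cc3C2)nn1`, 20600 nM
compound 3, `COc1cccc(Cn2cc(C(=O)NCCCCN3CCc4cc(OC)c(OC)cc4C3)nn2)c1`, 12700 nM

Compound 3 sits second highest of the three numbers. Its nearest neighbour is compound 1, with a 1.2-fold higher number from compound 1 to compound 3 (0.06 log units; within the scatter), and the furthest is compound 2, with a 1.6-fold lower number from compound 2 to compound 3 (0.21 log units; within the scatter); neither of these steps reaches beyond the scatter, and the same holds for a 1.9-fold higher number from compound 1 to compound 2 (0.27 log units; within the scatter). So far, the three compounds show no difference that can be told apart.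

Compound 4, `COc1cc2c(cc1OC)CN(CCCCNC(=O)c1cn(Cc3cccc(O)c3)nn1)CC2`, has not yet been measured. It differs from compound 3 only in one place: hydrogen in place of methyl on an oxygen on an aromatic ring. Within the data shown here, the steps that bear on this change are those that alter the benzyl group on the aromatic nitrogen, and all of them lie within the scatter, including the move from a 2-methoxyphenyl to a 3-methoxyphenyl that gives a 1.6-fold lower number from compound 2 to compound 3 (0.21 log units; within the scatter). Among the measured compounds shown here, nothing among the measured compounds tests a free hydroxy on that ring. A step of no more than the scatter, in either direction, is therefore expected from compound 3 to compound 4, that is a 1.1-fold lower number from compound 3 to compound 4 (0.02 log units; within the scatter). Compound 4 is estimated at 12000 nM, with a range from 5000 nM to 30000 nM.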

Compound 4, inhibition constant: 8080 nM
Beside the measured number, compound 4's estimate is 1.5-fold (0.17 log units) above it; low and high end bracket the measured number.
By their numbers in this assay, from the lowest: compounds 4, 1, 3 and 2 (each within the scatter of the next, the first and the last beyond it).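

In this assay, among these compounds, hydrogen in place of methyl on an oxygen on an aromatic ring puts a free hydroxy on this benzyl group for the first time, and the result is a 1.6-fold lower number from compound 3 to compound 4 (0.20 log units; within the scatter) and so cannot be told apart from no change. Setting the whole 3-hydroxybenzyl group in place of hydrogen on the aromatic nitrogen likewise gives a 1.4-fold lower number from compound 1 to compound 4 (0.13 log units; within the scatter) and stays within the scatter, whereas the comparison with the 2-methoxybenzyl group gives a 2.5-fold lower number from compound 2 to compound 4 (0.41 log units; beyond the scatter) and is a modest step, the only one in this set that passes the scatter, although it alters both the ring position of the oxygen substituent and the methyl on that oxygen and cannot tell these two changes apart. No measurement among the data offers an explanation for these numbers.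

As far as these compounds go, what remains open is whether a 2-hydroxybenzyl group on the same nitrogen would separate those two changes by reading directly against the 2-methoxybenzyl group of compound 2. Also open is how a 3-aminobenzyl or a 3-carboxybenzyl group in that place would read, as the compounds shown include neither an amine nor a carboxylic acid on this ring.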